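From allyl to benzyl on the ring nitrogen

The source may hold more compounds than are shown below. What is called first, only, known or untested is meant among the compounds shown, and "the series" means these compounds.

Compound 1 `C=CCN1[C@H](c2ccc([N+](=O)[O-])cc2)C(C(=O)OCC)C(=O)C(C(=O)OCC)[C@@H]1c1ccc([N+](=O)[O-])cc1` was tested in an ADME assay on J774.1 cells (Mus musculus) for cytotoxicity, with a stated time of 48 h; on this read-out higher numbers stand for an effect only at larger amounts of compound and lower numbers for an effect already at smaller amounts. In this assay compound 1 gives only a limit, > 100 uM, and so sits at the limit of > 100 uM in this assay, at which 1 of the 2 values shown sits. Compound 2 `COC(=O)C1C(=O)C(C(=O)OC)[C@H](c2ccccn2)N(Cc2ccccc2)[C@@H]1c1ccccn1` is the other measured compound; in this assay compound 2 gives 34 uM. Compound 3 `CCOC(=O)C1C(=O)C(C(=O)OCC)[C@H](c2ccc([N+](=O)[O-])cc2)N(Cc2ccccc2)[C@@H]1c1ccc([N+](=O)[O-])cc1` has not yet been measured. It differs from compound 1 in one place: phenyl in place of vinyl on a saturated chain carbon bound to an amine nitrogen in a ring, which, read one bond further out, is allyl to benzyl. Among the measured compounds shown here, no measured pair shows this change. Because compound 1 reports only the limit > 100 uM, the size of the step cannot be read from the measured numbers. Compound 2, which also carries a benzyl group, does give a number, 34 uM, and on that basis compound 3 is expected to give about 70 uM, between 25 uM and 200 uM. The step of an at least 1.4-fold lower number from compound 1 to compound 3 (0.15 log units; that floor lies within the scatter) is thus expected to run toward an effect at smaller amounts, with a fair chance that only a limit is returned.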

Compound 3, concentration for half-maximal effect: > 100 uM
Compound 3 ended at the assay's limit; the forecaster's own chance of this, stated with the estimate: 40%; middle value at least 1.4-fold (0.15 log units) away from the limit.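

Compound 3 joins compound 1 at a limit rather than a number: the limit of > 100 uM in this assay, at which 2 of the 3 values shown sit. Among the compounds shown here, no step from compound 1 to compound 3 can therefore be read. The compounds shown leave open whether allyl to benzyl on the shared core changes the result in this assay at all.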